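A second aryl substituent on the indole nitrogen side chain

The source may report more compounds than this note shows. Statements on the series, on what has been measured and on what is new or still open speak of the compounds shown alone.

Going by the values given here, the three compounds measured so far share one core and differ only in the branch on the saturated chain carbon bound to the aromatic nitrogen. Compound 1 `CCCCC(C)n1ccc2cc(/C(C)=C/C(=O)Nc3ccccc3OCCCC(=O)O)ccc21` gives 6 nM in an assay on Prostate gland for inhibition of steroid 5-alpha-reductase (Rattus norvegicus); a lower number here means a stronger inhibitor, a higher number a weaker inhibitor. Compound 2 `CCCCC(CCCC)n1ccc2cc(/C(C)=C/C(=O)Nc3ccccc3OCCCC(=O)O)ccc21` gives 21 nM. Compound 3 `CCCCC(c1ccccc1)n1ccc2cc(/C(C)=C/C(=O)Nc3ccccc3OCCCC(=O)O)ccc21` gives 9.8 nM, the second highest of the three numbers; its distance to compound 1 lies within the scatter, while a 2.1-fold lower number from compound 2 to compound 3 (0.33 log units; beyond the scatter) lies beyond it.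

Compound 4 `COc1ccc(C(c2ccccc2)n2ccc3cc(/C(C)=C/C(=O)Nc4ccccc4OCCCC(=O)O)ccc32)cc1` carries 4-methoxyphenyl in place of butyl on a saturated chain carbon bound to an aromatic carbon and an aromatic nitrogen. Among the compounds with values here, two measured steps bear on this change. a 2.1-fold lower number from compound 2 to compound 3 (0.33 log units; beyond the scatter) shows that an aromatic ring in place of a chain on this carbon lowered the number modestly, whereas a 1.6-fold higher number from compound 1 to compound 3 (0.21 log units; within the scatter) stayed within the scatter. Within the data shown here, compound 4 now places a second aromatic ring on the same carbon, a change for which no direct precedent exists among the measured compounds. He therefore expects the step from compound 3 to compound 4 to be small, a 1.2-fold higher number from compound 3 to compound 4 (0.09 log units; within the scatter), with no clear direction beyond the scatter. For compound 4 he estimates 12 nM in this assay, within a range from 4 nM to 40 nM.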

Compound 4, half-maximal inhibitory concentration: 8.8 nM
Beside the measured number, compound 4's estimate is 1.4-fold (0.13 log units) above it; measured number inside the range.
By their numbers in this assay, from the lowest: compounds 1, 4 and 3 (each within the scatter of the next); then compound 2.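

In this assay, 4-methoxyphenyl in place of butyl on a saturated chain carbon bound to an aromatic carbon and an aromatic nitrogen gives a 1.1-fold lower number from compound 3 to compound 4 (0.05 log units; within the scatter). The earlier compounds shown here carried at most one aromatic ring on this carbon, so compound 4 adds something new: a second aromatic ring can stand there, with its ring and its hydrogen-bond acceptor, and the number stays within the scatter of compound 3. This larger group therefore brings no measurable change at this position in this pair, and nothing in the data shown accounts for that.

On these data alone, it remains open what the methoxy group itself contributes, and whether a plain phenyl or a 4-aminophenyl on the same carbon would read like compound 4. Also open, as far as these compounds go, is whether a saturated ring such as cyclohexyl would fit this position as well as the aromatic rings do.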